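A few compounds are considered here, and "the series" means these few. Any claim that something is new, unique, unknown or untested is made for them only; others in the source may bear on it.

Compound 1 `Nc1cc(N)c2nc(-c3ccccc3)c(NCc3ccc(Cl)c(Cl)c3)nc2c1` is one of three close analogues on a shared core, and in a functional assay on SF-268 cells (Homo sapiens) for inhibition, read by sulforhodamine B assay, with a stated time of 48 h (on this read-out higher numbers stand for weaker inhibition of growth and lower numbers for stronger inhibition of growth), compound 1 gives 55000 nM. Compound 2 `Nc1cc(N)c2nc(-c3ccccc3)c(Sc3ccc(F)cc3)nc2c1` gives 38900 nM and compound 3 `Nc1cc(N)c2nc(-c3ccccc3)c(Oc3ccc(F)cc3)nc2c1` gives 47900 nM, so the value of compound 1 sits within the scatter of both of the others. Within the data shown here, the only single-place step among the measured compounds, a 1.2-fold higher number from compound 2 to compound 3 (0.09 log units; within the scatter), concerns a group on an aromatic carbon of the core and not the benzyl part. Compound 4 `COc1ccc(CNc2nc3cc(N)cc(N)c3nc2-c2ccccc2)cc1` differs from compound 1 by 4-methoxyphenyl in place of 3,4-dichlorophenyl on a saturated chain carbon bound to a nitrogen on an aromatic ring. Among the measured compounds shown here, no measured step touches this position, so there is no ground to expect a move beyond the scatter, and the three clustered values frame the range. Compound 4 is therefore estimated at 50000 nM, between 20000 nM and 120000 nM. The expected step is a 1.1-fold lower number from compound 1 to compound 4 (0.04 log units; within the scatter).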

Compound 4, concentration for total growth inhibition: 21900 nM
Compound 4: middle estimate off by 2.3-fold (0.36 log units), on the high side; measured number inside the range.
By their numbers in this assay, from the lowest: compounds 4, 2, 3 and 1 (each within the scatter of the next, the first and the last beyond it).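

The place on a saturated chain carbon bound to a nitrogen on an aromatic ring responds to substitution in this assay and the change from 3,4-dichlorobenzyl to 4-methoxybenzyl gives a 2.5-fold lower number from compound 1 to compound 4 (0.40 log units; beyond the scatter) as a modest step. This is the first step among these compounds that lies beyond the scatter, and the only earlier step concerned a different place.

The compounds shown leave open whether the loss of the chlorines or the arrival of the methoxy group matters, and how a 4-chlorobenzyl or a 4-aminobenzyl group would read here. No available evidence accounts for this step.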